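A few compounds are considered here, and "the series" means these few. Any claim that something is new, unique, unknown or untested is made for them only; others in the source may bear on it.

Compound 1, `Nc1ccccc1NC(=O)c1ccc(NC(=S)NCc2cccc(F)c2)cc1`: 5900 nM
Compound 3, `Nc1ccccc1NC(=O)c1ccc(NC(=S)NCc2ccccc2F)cc1`: 6300 nM
Compound 2, `Nc1ccccc1NC(=O)c1ccc(CNC(=O)c2cc3cccnc3[nH]2)cc1`: 10000 nM

In a functional assay on HCT-116 cells (Homo sapiens) for cytotoxicity, read by MTT assay, with a stated time of 72 h (on this read-out lower numbers stand for stronger inhibition and higher numbers for weaker inhibition), compound 1 stands lowest of the three numbers, though neither of the other two lies beyond the usual scatter of it. The nearest is compound 3, reached by a 1.1-fold higher number from compound 1 to compound 3 (0.03 log units; within the scatter); compound 2, with a different linker and a different terminal ring, gives the furthest of the three numbers but still one within the scatter of compound 1.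

Compound 4, `Nc1ccccc1NC(=O)c1ccc(NC(=S)NCc2cccnc2)cc1`, differs from compound 1 in one place: pyridin-3-yl in place of 3-fluorophenyl on a saturated chain carbon bound to an amide-type nitrogen. Within the data shown here, the only measured step that touches this position is the one from compound 1 to compound 3, where one fluorophenyl was exchanged for another and the number barely moved. Among the measured compounds shown here, no measured pair exchanges a fluorophenyl for a pyridinyl, so the data give no ground for a step beyond the scatter in either direction. Compound 4 is therefore expected to sit close to compound 1, with an estimated step of a 1.1-fold higher number from compound 1 to compound 4 (0.04 log units; within the scatter), an estimated 6500 nM in this assay, and a range from 3000 nM to 14000 nM.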

Compound 4, half-maximal inhibitory concentration: 1000 nM
Compound 4: the middle estimate sits 6.5-fold (0.81 log units) above what was measured, and the stated range ends above it.
By their numbers in this assay, from the lowest: compound 4; then compounds 1, 3 and 2 (each within the scatter of the next).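

In this assay this position proves sensitive to the kind of ring it carries: pyridin-3-yl gives a 5.9-fold lower number from compound 1 to compound 4 (0.77 log units; beyond the scatter) and also a 6.3-fold lower number from compound 3 to compound 4 (0.80 log units; beyond the scatter), while the exchange of 3-fluorophenyl for 2-fluorophenyl had given only a 1.1-fold higher number from compound 1 to compound 3 (0.03 log units; within the scatter) within the scatter. The earlier pair therefore showed that the number tolerates this exchange between fluorophenyl groups, not that the position as a whole is indifferent, since both steps to compound 4 lie beyond the scatter. Nothing measured on these compounds explains why the pyridin-3-yl compound gives the lower number.

What pyridin-2-yl or pyridin-4-yl would give at this position stays open, so the compounds shown cannot tell whether the place of the ring nitrogen matters. On these data alone, it is also open whether plain phenyl or a morpholine ring on the same chain carbon would follow the fluorophenyl compounds or compound 4.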